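The source may hold more compounds than are shown below. What is called first, only, known or untested is meant among the compounds shown, and "the series" means these compounds.

The measured compounds:
compound 1, `Nc1nn2c(O)cc(-c3ccccc3F)nc2c1[N+](=O)[O-]`, gives 66.5 ug/mL in an ADME assay (Homo sapiens) for cytotoxicity; on this read-out lower numbers stand for higher toxicity in this test and higher numbers for lower toxicity in this test.
compound 2, `Nc1nn2c(O)cc(-c3ccc(F)cc3)nc2c1[N+](=O)[O-]`, gives > 100 ug/mL, which is a limit of the assay rather than a number.
compound 3, `Nc1nn2c(O)cc(CNNc3ccc(S(=O)(=O)O)cc3)nc2c1[N+](=O)[O-]`, gives > 50 ug/mL, also a limit of the assay.

Compound 1 thus stands as the only one of the three with a real number in this assay; the other two sit at limits, one of them at the limit of > 100 ug/mL in this assay, at which 1 of the 3 values shown sits, and the other at the limit of > 50 ug/mL in this assay, at which 1 of the 3 values shown sits. Compound 4, `Nc1nn2c(O)cc(CNCCO)nc2c1[N+](=O)[O-]`, has not been measured. The change from compound 1 to compound 4 is ((2-hydroxyethyl)amino)methyl in place of 2-fluorophenyl on an aromatic carbon. Within the data shown here, only one measured step touches the same place: an at least 1.5-fold higher number from compound 1 to compound 2 (0.17 log units; that floor lies within the scatter), and that step stays within the scatter. Compound 3 carries a different group without a ring at that same place, and its value is a limit only. Among the measured compounds shown here, nothing among the measured steps points to a higher toxicity after such a change; rather, the measured values cluster near the top of the assay's range. The step to compound 4 is therefore expected to be a 1.4-fold higher number from compound 1 to compound 4 (0.13 log units; within the scatter), a shift toward a higher number that may not exceed the scatter. For compound 4 the expected value in this assay is 90 ug/mL, within a range from 50 ug/mL to 160 ug/mL.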

Compound 4, half-maximal cytotoxic concentration: > 50 ug/mL
Compound 4 ended at the assay's limit; the forecaster's own chance of this, stated with the estimate: 45%; the middle value does not contradict the limit.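

Compound 4 gives > 50 ug/mL, which is a limit of the assay and not a number. Among these compounds, no step from compound 1 to compound 4, or from compound 2 to compound 4, can be read from it. The compounds shown leave open how ((2-hydroxyethyl)amino)methyl truly compares with 2-fluorophenyl or 4-fluorophenyl in this assay.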